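The compounds below may be only part of what the source reports. "The series", "measured", "known", "first", "only" and "open" are said of these compounds alone.

In an in vivo ADME assay on the whole organism (Cavia porcellus) (on this read-out higher numbers stand for a longer-lived compound and lower numbers for a shorter-lived compound), compound 1 (`CCC(NC(=O)c1ccc(C(=N)N)cc1)C(C)(C)C(=O)N1CCC(CC(=O)O)CC1`) gives 1.3 h and compound 2 (`CC(NC(=O)c1ccc(C(=N)N)cc1F)C(C)(C)C(=O)N1CCC(CC(=O)O)CC1`) gives 1.4 h, two values that lie within the usual scatter of each other. Compound 3 (`CCC(NC(=O)c1ccc(C(=N)N)cc1F)C(C)(C)C(=O)N1CCC(CC(=O)O)CC1`) differs from compound 2 in one place: methyl in place of hydrogen on a saturated chain carbon, two bonds along the chain from an amide-type nitrogen. Among the compounds with values here, no measured pair shows this change alone, so no shift beyond the scatter is expected, in either direction. The expected outcome is a step of no change at the digits printed from compound 2 to compound 3 (within the scatter). For compound 3 the estimated half-life is 1.4 h, with a range from 0.8 h to 2.4 h.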

Compound 3, half-life: 1.48 h
Compound 3: the middle estimate sits 1.1-fold (0.02 log units) below what was measured, and the stated range covers the measured number.
By their numbers in this assay, from the lowest: compounds 1, 2 and 3 (each within the scatter of the next).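

In this assay, methyl in place of hydrogen on a saturated chain carbon, two bonds along the chain from an amide-type nitrogen, gives a 1.1-fold higher number from compound 2 to compound 3 (0.02 log units; within the scatter). Fluoro in place of hydrogen on an aromatic carbon, seen here as a single change for the first time, gives a 1.1-fold higher number from compound 1 to compound 3 (0.06 log units; within the scatter), so neither small change separates these compounds on half-life. Nothing available explains this result.

Going by these compounds, whether a longer chain such as propyl, or a hydroxyl group, on this same chain carbon would move the half-life beyond the scatter remains open. So does the outcome of chloro in place of fluoro on the aromatic carbon.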